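Ethyl for cyano on the pyridine ring of compound 2

A few compounds are considered here, and "the series" means these few. Any claim that something is new, unique, unknown or untested is made for them only; others in the source may bear on it.

Measured compounds:
compound 1 `N#Cc1cccc(C#Cc2cccc(C(N)=O)c2)n1`, > 10000 nM
compound 2 `N#Cc1cccc(C#Cc2cccc(C#N)n2)c1`, 8.2 nM

Compound 1 `N#Cc1cccc(C#Cc2cccc(C(N)=O)c2)n1` reaches only a limit in an assay on membranes from brain (strain Sprague-Dawley) for displacement of a labelled ligand from metabotropic glutamate receptor 5 (Rattus norvegicus), read by scintillation counting, with a stated time of 60 min (a lower number here means a stronger inhibitor, a higher number a weaker inhibitor), namely > 10000 nM; this is the limit of > 10000 nM in this assay, at which 1 of the 2 values shown sits. Compound 2 `N#Cc1cccc(C#Cc2cccc(C#N)n2)c1` in this assay gives 8.2 nM, the only real number shown. Within the data shown here, the one step between them, an at least 1200-fold lower number from compound 1 to compound 2 (3.08 log units; beyond the scatter), is large, and concerns the group on the phenyl ring.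

Compound 3 `CCc1cccc(C#Cc2cccc(C#N)c2)n1` differs from compound 2 at the other ring: ethyl in place of cyano on an aromatic carbon. Among the measured compounds shown here, no measured step touches this position, so the step from compound 1 to compound 2 bears on it only in showing that this assay spans a wide range; it gives no direct guide to the size or direction of the new change. The expectation for compound 3 therefore rests mainly on compound 2 as the starting point, with a moderate loss allowed for.

Compound 3 is estimated at 25 nM, between 5 nM and 150 nM, a step of a 3.0-fold higher number from compound 2 to compound 3 (0.48 log units; beyond the scatter) that is expected to stay close to the scatter.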

Compound 3, inhibition constant: 3.4 nM
Estimate against measurement, compound 3: 7.4-fold (0.87 log units) above, outside the stated range (below it).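

In this assay, the carbon next to the ring nitrogen does not depend on the cyano group for a low number: ethyl in its place gives a 2.4-fold lower number from compound 2 to compound 3 (0.38 log units; beyond the scatter), a modest change that lies beyond the scatter. The hydrogen-bond acceptor that leaves with the cyano group is therefore not needed at this place, and this change is far smaller than the one on the other ring, an at least 1200-fold lower number from compound 1 to compound 2 (3.08 log units; beyond the scatter). Nothing measured here gives a reason for the direction of the new step.

As far as these compounds go, what remains open is how far this tolerance extends, since only cyano and ethyl are compared at this position, and a methyl group, a longer chain such as propyl, a methoxy group or an amine could each behave differently. It is also open whether the large effect of exchanging cyano for carbamoyl on the other ring would be repeated with ethyl in place, as the compounds shown include no carbamoyl partner for compound 3.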